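Chloro for Fluoro: What to Expect of Compound 3

This account rests on a few compounds, and the source may have more. Where it says the series, first, only, none or still open, it means among the compounds named here.

Of the compounds shown here, two have been measured so far in an assay on tissue (HeLa cells) for inhibition of Indoleamine 2,3-dioxygenase 1 (Homo sapiens), read by spectrophotometry; on this read-out lower numbers stand for stronger inhibition and higher numbers for weaker inhibition. Compound 2 `O/N=C(/Nc1ccc(F)c(F)c1)c1ccc2occc2c1` gives 14000 nM, while compound 1 `O/N=C(/Nc1cccc(F)c1)c1ccc2occc2c1` gives 20000 nM; compound 2 holds the smaller of the two numbers, yet the gap is within the scatter, as the step shows: a 1.4-fold lower number from compound 1 to compound 2 (0.15 log units; within the scatter). Compound 3 `O/N=C(/Nc1ccc(Cl)c(F)c1)c1ccc2occc2c1` differs from compound 2 by chloro in place of fluoro on an aromatic carbon. Within the data shown here, no measured step swaps one halogen for another; the only step recorded, adding a fluoro group, stayed within the scatter. A similarly small step, if any, is therefore expected in this assay. Compound 3 is estimated at 10000 nM, within 4000 nM to 30000 nM, a step of a 1.4-fold lower number from compound 2 to compound 3 (0.15 log units; within the scatter).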

Compound 3, half-maximal inhibitory concentration: 10300 nM
Beside the measured number, compound 3's estimate is 1.0-fold (0.01 log units) below it; low and high end bracket the measured number.
By their numbers in this assay, from the lowest: compounds 3, 2 and 1 (each within the scatter of the next).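

This position, para to a large group and ortho to a fluoro group, now has a measured halogen swap: in this assay, chloro for fluoro gives a 1.4-fold lower number from compound 2 to compound 3 (0.13 log units; within the scatter). Chloro for hydrogen on this same carbon gives a 1.9-fold lower number from compound 1 to compound 3 (0.29 log units; within the scatter), so neither change here moves the number beyond the scatter. No measured data explain why these steps are small.

As far as these compounds go, whether an amine or a carboxylic acid on this carbon would give a step beyond the scatter remains open. So does the effect of chloro here without the ortho fluoro group.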